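Acetyl for Pivaloyl on the Piperazine Amide

The source may hold more compounds than are shown below. What is called first, only, known or untested is meant among the compounds shown, and "the series" means these compounds.

The series shares one core. Compound 1 `COc1cc2nc(N3CCN(C(C)=O)[C@@H]4CCCC[C@@H]43)nc(N)c2cc1OC` and compound 2 `COc1cc2nc(N3CCN(C(=O)C(C)(C)C)[C@H]4CCCC[C@H]43)nc(N)c2cc1OC` are measured in an assay on CHO cells for displacement of a labelled ligand from Alpha-1B adrenergic receptor (Homo sapiens), with a stated time of 30 min; on this read-out higher numbers stand for weaker inhibition and lower numbers for stronger inhibition: compound 1 gives 0.741 nM, and compound 2 gives 0.776 nM, the higher of the two numbers, though the gap to compound 1 lies within the scatter. Compound 3 `COc1cc2nc(N3CCN(C(C)=O)[C@H]4CCCC[C@H]43)nc(N)c2cc1OC` follows from compound 2 by methyl in place of tert-butyl on a carbonyl carbon. Since compound 1 already carries an acetyl group and gives 0.741 nM, no shift beyond the scatter is expected a 1.0-fold lower number from compound 2 to compound 3 (0.01 log units; within the scatter). Compound 3 is therefore estimated at 0.75 nM, within 0.35 nM to 1.6 nM.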

Compound 3, inhibition constant: 9.12 nM
Compound 3: the middle estimate sits 12-fold (1.08 log units) below what was measured; the whole stated range lies below it.
By their numbers in this assay, from the lowest: compounds 1 and 2 (each within the scatter of the next); then compound 3.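

With the configuration of compound 2 held, the group on the carbonyl carbon matters in this assay: methyl in place of tert-butyl gives a 12-fold higher number from compound 2 to compound 3 (1.07 log units; beyond the scatter). An acetyl group therefore does not by itself fix the number, and the configuration counts as well. The step of a 12-fold higher number from compound 1 to compound 3 (1.09 log units; beyond the scatter) can be assigned to configuration alone because of one fact: the fact that compounds 1 and 3 differ only in the configuration as drawn

Open, as far as these compounds go, is how an ethyl group, a longer chain or a phenyl ring on the carbonyl carbon would read in either configuration. Also open, from the compounds shown here alone, is how tert-butyl would read in the configuration of compound 1.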